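Trimming a Methoxyphenyl Arm Down to Hydrogen

This account rests on a few compounds, and the source may have more. Where it says the series, first, only, none or still open, it means among the compounds named here.

Of the compounds shown here, three sharing one core have been measured in a functional assay on PC-3 cells (Homo sapiens) for cytotoxicity, read by MTT assay, with a stated time of 72 h; on this read-out higher numbers stand for weaker inhibition and lower numbers for stronger inhibition. Compound 1 `CCCOCNc1n[n+]([O-])c2cc(OC)ccc2[n+]1[O-]` gives 10600 nM, compound 2 `[O-][n+]1nc(NCOCc2ccc(C(F)(F)F)cc2)[n+]([O-])c2ccccc21` gives 9310 nM, and compound 3 `COc1ccc(COCNc2n[n+]([O-])c3ccccc3[n+]2[O-])cc1` gives 52800 nM. Compound 3 stands highest of the three, with compound 1 nearest and compound 2 furthest. For the measured compounds named here, the only single-point step so far is a 5.7-fold higher number from compound 2 to compound 3 (0.75 log units; beyond the scatter). Compound 4 `COCNc1n[n+]([O-])c2ccccc2[n+]1[O-]` differs from compound 3 by hydrogen in place of 4-methoxyphenyl on a saturated chain carbon bound to an oxygen on a saturated carbon. Going by the values given here, no measured step removes this whole ring, so the change has no direct precedent; the closest guide is compound 1, which carries no such ring and gives 10600 nM. Compound 4 is therefore expected to land near that, a step of a 3.5-fold lower number from compound 3 to compound 4 (0.55 log units; beyond the scatter). The estimate for compound 4 is 15000 nM, ranging from 5000 nM to 50000 nM.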

Compound 4, half-maximal inhibitory concentration: 4270 nM
Estimate against measurement, compound 4: 3.5-fold (0.55 log units) above; the whole stated range lies above it.
By their numbers in this assay, from the lowest: compound 4; then compounds 2 and 1 (each within the scatter of the next); then compound 3.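

In this assay, putting hydrogen in place of 4-methoxyphenyl on a saturated chain carbon bound to an oxygen on a saturated carbon gives a 12-fold lower number from compound 3 to compound 4 (1.09 log units; beyond the scatter), a large step. This shows that the 4-methoxyphenyl ring is not needed for activity in this series, and that compound 3 is more active without it. No measurement shown explains the drop.

Still open, on these data alone, is how the number changes between these two extremes, with an ethyl group or an unsubstituted phenyl ring on that carbon. An amine or a carboxylic acid at the end of this arm also remains untested in the compounds shown.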